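The compounds below may be only part of what the source reports. "The series", "measured", "known", "first", "only" and "open" are said of these compounds alone.

Measured in an ADME assay on cells (Hepatocyte, Homo sapiens) for metabolic stability; on this read-out higher numbers stand for a longer-lived compound and lower numbers for a shorter-lived compound:
Compound 1 `CS(=O)(=O)NC1CCC(CN2CCN(c3cc(=O)c4cc(C(F)(F)F)cc([N+](=O)[O-])c4s3)CC2)CC1`: > 1.55 h
Compound 2 `O=C(OC1CCC(CN2CCN(c3cc(=O)c4cc(C(F)(F)F)cc([N+](=O)[O-])c4s3)CC2)CC1)c1ccncc1`: 0.075 h
Compound 3 `Cc1ccc(C(=O)OC2CCC(CN3CCN(c4cc(=O)c5cc(C(F)(F)F)cc([N+](=O)[O-])c5s4)CC3)CC2)cc1`: 0.148 h

The value for compound 1 is a limit, not a number. Compound 3 lies within the scatter of compound 2, with a 2.0-fold higher number from compound 2 to compound 3 (0.30 log units; within the scatter). Both lie far from compound 1: an at least 20-fold lower number from compound 1 to compound 2 (1.31 log units; beyond the scatter) and an at least 10-fold lower number from compound 1 to compound 3 (1.02 log units; beyond the scatter).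

Compound 4 `O=C(OC1CCC(CN2CCN(c3cc(=O)c4cc(C(F)(F)F)cc([N+](=O)[O-])c4s3)CC2)CC1)c1ccc(F)cc1` has fluoro in place of methyl on an aromatic carbon, para to a large group (fluoro in place of methyl on an aromatic carbon). Among the compounds with values here, the closest precedent is the swap on the carbonyl carbon between compound 2 and compound 3, a 2.0-fold higher number from compound 2 to compound 3 (0.30 log units; within the scatter). The large steps replace the whole methanesulfonamido group, which compound 4 does not do. The estimated step, a 1.2-fold lower number from compound 3 to compound 4 (0.09 log units; within the scatter), is therefore not expected to exceed the scatter in this assay. Compound 4 is expected at 0.12 h, with an estimated range of 0.06 h to 0.25 h.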

Compound 4, half-life: 0.0983 h
The estimate for compound 4 lay 1.2-fold (0.09 log units) above the measured number, within the range that was stated.
By their numbers in this assay, from the lowest: compounds 2, 4 and 3 (each within the scatter of the next). At a limit, above all of these: compound 1.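

In this assay, fluoro in place of methyl on the aromatic carbon para to a large group gives a 1.5-fold lower number from compound 3 to compound 4 (0.18 log units; within the scatter) and adds a third aryl group to the series, with 4-fluorophenyl in place of pyridin-4-yl giving a 1.3-fold higher number from compound 2 to compound 4 (0.12 log units; within the scatter) on the same carbonyl carbon. The aryl swaps thus stay within the scatter, while the change from methanesulfonamido remains large: an at least 15-fold lower number from compound 1 to compound 4 (1.19 log units; beyond the scatter) and this step rests on a limit. Compound 1 gives a limit, not a number: the limit of > 1.55 h in this assay, at which 1 of the 4 values shown sits.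

Open, from the compounds shown here alone, is whether the short half-life follows the carbonyloxy link itself. A hydroxyl, an amine or a carboxamide on the saturated ring carbon would bear on this.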